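A few compounds are considered here, and "the series" means these few. Any claim that something is new, unique, unknown or untested is made for them only; others in the source may bear on it.

Measured compounds in a functional assay on the whole organism (strain BALB/c) for inhibition, with Mus musculus as the target, read by paw edema, with a stated time of 4 h, at a dose of 50 mg/kg by the oral route; a lower number here means less inhibition, a higher number more inhibition at the dose given (going by the name of the read-out):
- compound 1, `CCNc1nnc(-c2cc(-c3ccc(F)cc3F)ccc2O)s1`: 50.2%
- compound 2, `C=CCNc1nnc(-c2cc(-c3ccc(F)cc3F)ccc2O)s1`: 57.2%

Within the data shown here, compound 2 and compound 1 sit within the usual scatter of each other in this assay, the only measured step being a number 7 percentage points higher from compound 1 to compound 2 (within the scatter). The two numbers can therefore only be called level on what is shown.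

Compound 3, `Oc1ccc(-c2ccc(F)cc2F)cc1-c1nnc(NC2CCCCC2)s1`, differs from compound 2 by cyclohexyl in place of allyl on a nitrogen on an aromatic ring. Among the measured compounds shown here, the one measured step bears on it only loosely: it also changes the group carried on that ring nitrogen, and it stayed within the scatter. Nothing measured here shows how a ring in that position, rather than a short chain, behaves. The expected step in this assay is a number 2.2 percentage points lower from compound 2 to compound 3 (within the scatter), that is, no change beyond the scatter. On that basis compound 3 is estimated to give 55% in this assay, with a range from 38% to 72%.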

Compound 3, a percentage reported as inhibition, in the whole organism at one dose (the size of the read-out at that dose, not a potency): 41.4%
The estimate for compound 3 lay 13.6 percentage points above the measured number; the measured number falls inside the stated range.
By their numbers in this assay, from the lowest: compounds 3, 1 and 2 (each within the scatter of the next, the first and the last beyond it).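

Among these compounds, putting a ring on this nitrogen gives the only step here that clearly moves the number in this assay: cyclohexyl in place of allyl gives a number 15.8 percentage points lower from compound 2 to compound 3 (beyond the scatter) while cyclohexyl in place of ethyl gives a number 8.8 percentage points lower from compound 1 to compound 3 (within the scatter) and so leaves the two compounds level. The position therefore does respond to the group it carries, but compound 3 can be told apart only from compound 2, not from compound 1. No measurement at hand explains this difference.

The compounds shown leave open whether a smaller ring such as cyclopropyl would behave like cyclohexyl, or whether an open hexyl chain would do the same, so the effect of the ring cannot yet be separated from that of the carbon count. Also open, on these data alone, is what phenyl, or a plain amino group with no carbon group on the nitrogen, would give here.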